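Oxime-ether series: benzothiazole in place of thiazole

A few compounds are considered here, and "the series" means these few. Any claim that something is new, unique, unknown or untested is made for them only; others in the source may bear on it.

Measured so far:
Compound 1, `CC(/C=C/C(=O)O)=N\OC(c1ccc(OCc2ccc3ccccc3n2)cc1)C1CCCCC1`: 40 nM
Compound 2, `C/C(=N\OC(c1ccc(OCc2cscn2)cc1)C1CCCCC1)C(=O)O`: 360 nM

In a functional assay for inhibition of Polyunsaturated fatty acid 5-lipoxygenase (Homo sapiens) (a higher number here means a weaker inhibitor, a lower number a stronger inhibitor), compound 2 gives 360 nM, the higher of the two numbers shown; compound 1 gives 40 nM in this assay, and the gap between the two lies beyond the scatter. The two compounds differ in more than one place, so no single step can be read from them.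

Compound 3, `C/C(=N\OC(c1ccc(OCc2nc3ccccc3s2)cc1)C1CCCCC1)C(=O)O`, is not yet measured. It differs from compound 2 in one place: 1,3-benzothiazol-2-yl in place of 1,3-thiazol-4-yl on a saturated chain carbon bound to an oxygen on an aromatic ring. Nothing else in the structure changes.

For the measured compounds named here, the only guide is that compound 1, which also carries a bicyclic aromatic group on that chain carbon, gives the lower number 40 nM. The expected step is a 3.3-fold lower number from compound 2 to compound 3 (0.51 log units; beyond the scatter), towards a lower number, of a size beyond the scatter. Compound 3 is expected to give about 110 nM in this assay, estimated within 30 nM to 400 nM.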

Compound 3, half-maximal inhibitory concentration: 60 nM
Estimate against measurement, compound 3: 1.8-fold (0.26 log units) above, within the range that was stated.
By their numbers in this assay, from the lowest: compounds 1 and 3 (each within the scatter of the next); then compound 2.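

In this assay, the place on a saturated chain carbon bound to an oxygen on an aromatic ring proves sensitive to the group it carries: 1,3-benzothiazol-2-yl in place of 1,3-thiazol-4-yl gives a 6.0-fold lower number from compound 2 to compound 3 (0.78 log units; beyond the scatter) with nothing else in the structure changed. For the compounds shown here, this is the first step that can be read in one place, since compound 1 and compound 2 differ in more than one. No measurement available here bears on the reason for this step.

The change adds a six-membered aromatic ring of carbon only and also alters the point of attachment, so the contribution of each remains unresolved. A 1,3-thiazol-2-yl group would separate the two, while a 1,3-benzoxazol-2-yl group would test whether the ring sulfur matters.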